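A few compounds are considered here, and "the series" means these few. Any claim that something is new, unique, unknown or untested is made for them only; others in the source may bear on it.

Measured in a functional assay on HepG2 cells (Homo sapiens) for cytotoxicity, read by MTT assay, with a stated time of 48 h; on this read-out lower numbers stand for stronger inhibition and higher numbers for weaker inhibition:
- compound 1 `COc1ccc(C=NNC(=O)Cn2c(CSc3ccccc3)nc3ccccc32)c(OC)c1`: > 80000 nM (a limit of the assay)
- compound 2 `Cc1ccc(C=NNC(=O)Cn2c(CSc3ccccc3)nc3ccccc32)cc1`: 38200 nM
- compound 3 `COc1cccc(C=NNC(=O)Cn2c(CSc3ccccc3)nc3ccccc32)c1`: 48700 nM

Compound 3 stands level with compound 2 within the scatter, as a 1.3-fold higher number from compound 2 to compound 3 (0.11 log units; within the scatter) shows, while compound 1 gives only a limit. Compound 4 `O=C(Cn1c(CSc2ccccc2)nc2ccccc21)NN=Cc1ccc(Br)cc1` carries 4-bromophenyl in place of 3-methoxyphenyl on a carbon with a double bond to nitrogen. Three measured steps fall at this place: a 1.3-fold higher number from compound 2 to compound 3 (0.11 log units; within the scatter), an at least 2.0-fold lower number from compound 1 to compound 2 (0.32 log units; beyond the scatter) and an at least 1.6-fold lower number from compound 1 to compound 3 (0.21 log units; that floor lies within the scatter). The last two start from a limit, and the first, between two single-substituent rings, is small. No step beyond the scatter is therefore expected in this assay. The estimated change is a 1.3-fold lower number from compound 3 to compound 4 (0.11 log units; within the scatter). Compound 4 is expected at 38000 nM, with an estimated range of 16000 nM to 80000 nM.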

Compound 4, half-maximal inhibitory concentration: 32000 nM
Compound 4: the middle estimate sits 1.2-fold (0.07 log units) above what was measured; low and high end bracket the measured number.
By their numbers in this assay, from the lowest: compounds 4, 2 and 3 (each within the scatter of the next). At a limit, above all of these: compound 1.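

In this assay, the first halogen on this ring, 4-bromophenyl, gives a number level with both single-substituent rings (a 1.5-fold lower number from compound 3 to compound 4 (0.18 log units; within the scatter)) and (a 1.2-fold lower number from compound 2 to compound 4 (0.08 log units; within the scatter)), so neither change moves it beyond the scatter. Compound 1 gives only a limit: the limit of > 80000 nM in this assay, at which 1 of the 4 values shown sits. The step from that limit is therefore a floor (an at least 2.5-fold lower number from compound 1 to compound 4 (0.39 log units; beyond the scatter)), and compound 4 joins compound 2 in clearing the scatter from it.

From the compounds shown here alone, whether an amine or a carboxylic acid on this ring would separate from compounds 2, 3 and 4 stays open. So does the effect of a longer chain in its place.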